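Removing one decyloxy chain from the dialkoxyphenyl amide series

The source may report more compounds than this note shows. Statements on the series, on what has been measured and on what is new or still open speak of the compounds shown alone.

Measured so far:
- compound 1, `CCCCCCCCCCOc1cc(OCCCCCCCCCC)cc(OCCCCCC(=O)N(c2ccc(C(=O)O)cc2)c2cccc(C(=O)O)c2)c1`: 53%
- compound 2, `CCCCCCCCCCOc1cc(OCCCCCCCCCC)cc(OCCCCCC(=O)N(Cc2ccc(C(=O)O)cc2)c2cccc(C(=O)O)c2)c1`: 92%

Both compounds were tested in an assay on isolated protein for binding affinity to L-selectin (Homo sapiens), read by ELISA, tested at 500 uM; a higher number here means more inhibition at the concentration tested (going by the name of the read-out), a lower number less inhibition. Within the data shown here, compound 1 gives 53%, and compound 2 gives 92%, the higher of the two numbers; the only measured step, a number 39 percentage points higher from compound 1 to compound 2 (beyond the scatter), concerns the group on the amide nitrogen and leaves the core unchanged.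

Compound 3, `CCCCCCCCCCOc1cccc(OCCCCCC(=O)N(Cc2ccc(C(=O)O)cc2)c2cccc(C(=O)O)c2)c1`, is the next candidate. It differs from compound 2 by hydrogen in place of decyloxy on an aromatic carbon. Among the measured compounds shown here, no measured step touches a decyloxy group, so nothing in this assay bears directly on the change; both measured compounds carry two such chains, and neither step says how many are needed. The expectation is a drop, estimated as a number 22 percentage points lower from compound 2 to compound 3 (beyond the scatter), because the whole measured range rests on the two-chain core of compound 2 with 92%. For compound 3 the estimated value in this assay is 70%, with a range from 40% to 95%.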

Compound 3, a percentage reported as inhibition, at one concentration (the size of the read-out at that concentration, not a potency): 103%
The estimate for compound 3 lay 33 percentage points below the measured number; measured number outside the range, above it.
By their numbers in this assay, from the lowest: compound 1; then compound 2; then compound 3.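

In this assay, this position does not need a decyloxy group: hydrogen in place of decyloxy on an aromatic carbon gives a number 11 percentage points higher from compound 2 to compound 3 (beyond the scatter) and the number does not fall. Compound 3, with a single decyloxy group left on the ring, gives 103% at the concentration tested, so the two-chain arrangement of compound 2 is not a requirement for inhibition in this series. Nothing measured here accounts for the rise.

As far as these compounds go, whether the remaining decyloxy group of compound 3 is itself needed stays open, as does whether a methoxy or hydroxyl group in the freed position would give a similar number. Also open, from the compounds shown here alone, is whether the 4-carboxyphenyl and 4-carboxybenzyl groups on the amide nitrogen would differ on the one-chain core as they do on the two-chain core.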